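The source may report more compounds than this note shows. Statements on the series, on what has been measured and on what is new or still open speak of the compounds shown alone.

This account follows one step in an ADME assay for permeability (a higher number here means that the compound crosses the layer faster, a lower number that the compound crosses the layer more slowly), from compound 1 to compound 4. Of the compounds shown here, three have been measured. Compound 1, `CNC(=O)c1cc(C(=O)N[C@H]2CC[C@H](O)CC2)c([C@@H](C)c2cccc(Cl)c2)o1`, gives 150 nm/s in this assay. Compound 2, `CNC(=O)c1cc(C(=O)N[C@H]2[C@@H]3COC[C@@H]32)cc2c1O[C@H](CF)[C@H]2c1ccccc1`, gives 165 nm/s, and compound 3, `CNC(=O)c1cc(C(=O)NC)n([C@@H](C)c2ccccc2)n1`, gives 280 nm/s. Compound 1 sits at one end of these three numbers, but both compound 2 and compound 3 lie within the usual scatter of it, so the three measured compounds cannot be told apart with confidence in this assay.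

Compound 4, `CNC(=O)c1cc(C(=O)N[C@H]2CC[C@H](O)CC2)c([C@@H](C)c2ccccc2)o1`, has not yet been measured. It differs from compound 1 in one place: hydrogen in place of chloro on an aromatic carbon. The 1-(3-chlorophenyl)ethyl of compound 1 becomes a 1-phenylethyl in compound 4, with no change elsewhere in the shared core or in the amide side chains.

Within the data shown here, no pair of measured compounds isolates this change, so there is no measured step to lean on. From the structural change alone, the step from compound 1 to compound 4 is expected to be small, a 1.3-fold lower number from compound 1 to compound 4 (0.10 log units; within the scatter), leaning slightly toward a lower number but not beyond the scatter. Compound 4 is therefore estimated at 120 nm/s in this assay, with a range of 70 nm/s to 220 nm/s.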

Compound 4, apparent permeability in the ADME assay: 42 nm/s
Estimate against measurement, compound 4: 2.9-fold (0.46 log units) above, outside the stated range (below it).
By their numbers in the ADME assay, from the lowest: compound 4; then compounds 1, 2 and 3 (each within the scatter of the next).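

Among these compounds, the chloro on the 3-chlorophenyl is not a silent substituent: in the ADME assay, replacing it with hydrogen gives a 3.6-fold lower number from compound 1 to compound 4 (0.55 log units; beyond the scatter), the only measured step here that isolates a single change and stands beyond the scatter. The same change also registers in a physicochemical assay for lipophilicity (a higher number here means a more lipophilic compound, a lower number a more polar compound), as a number 0.70 log units lower from compound 1 to compound 4 (beyond the scatter), so both read-outs respond to this one aromatic carbon. In the physicochemical assay compound 1 gives 3.5 and compound 4 gives 2.8. The slower crossing of the layer may be due to the lower lipophilicity that comes with losing the chlorine, although this reading rests on a single pair of compounds: the measured distribution coefficient of compound 1, 3.5, and of compound 4, 2.8, a number 0.70 log units lower (beyond the scatter)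

These compounds leave open whether a fluoro, methyl or methoxy group on the same aromatic carbon would bring the number in the ADME assay back toward that of compound 1, and whether any such recovery would follow the number in the physicochemical assay. They also leave open whether a chloro on the phenyl of compound 3, which has a different shared core, would produce a step of similar size.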